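Diethylamino Extension of Compound 2 in the Writhing Test

This account rests on a few compounds, and the source may have more. Where it says the series, first, only, none or still open, it means among the compounds named here.

compound 1 `CCn1nc(C)c2c(C)cc(=O)oc21`: 24.9 mg/kg
compound 2 `CCn1nc2oc(=O)cc(C)c2c1C`: 14.6 mg/kg
compound 3 `Cc1cc(O)oc2nncc1-2`: 40.6 mg/kg

These three compounds were measured in a functional assay on the whole organism with Mus musculus as the target, in the writhing test; a lower number here means that less compound is needed, a higher number that more compound is needed for the effect. Compound 2 gives the lowest of the three numbers; compound 1 stands within the scatter of it, compound 3 beyond it. Compound 4 `CCN(CC)CCn1nc2oc(=O)cc(C)c2c1C` has not been measured yet. It differs from compound 2 by diethylamino in place of hydrogen on a saturated chain carbon, two bonds along the chain from an aromatic nitrogen. For the measured compounds named here, no measured pair shows a change of this kind, so its effect in this assay cannot be read from the numbers at hand. The step from compound 2 to compound 4 is expected to be small, a 1.2-fold lower number from compound 2 to compound 4 (0.09 log units; within the scatter), most likely within the scatter in either direction. Compound 4 is estimated at 12 mg/kg, within a range from 5 mg/kg to 30 mg/kg.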

Compound 4, dose for half-maximal effect: 100 mg/kg
Compound 4: middle estimate off by 8.3-fold (0.92 log units), on the low side, and the stated range ends below it.
By their numbers in this assay, from the lowest: compounds 2, 1 and 3 (each within the scatter of the next, the first and the last beyond it); then compound 4.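

The saturated chain carbon, two bonds along the chain from an aromatic nitrogen, proves sensitive to substitution: in this assay diethylamino in place of hydrogen there gives a 6.8-fold higher number from compound 2 to compound 4 (0.84 log units; beyond the scatter) and thus a change beyond the scatter. For the compounds shown here, this is the only single-place change at hand, and with this group present more compound is needed for the effect. Nothing available accounts for this rise. Going by these compounds, whether dimethylamino or a carboxylic acid at the same place would give a similar number stays open, as does whether the amine nitrogen or the added carbons matter more.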